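Urea nitrogen substituents near the assay limit

A few compounds are considered here, and "the series" means these few. Any claim that something is new, unique, unknown or untested is made for them only; others in the source may bear on it.

Compound 1 `CC(C)CN(CC(C)C)c1ccc(/C(=N/O)Nc2ccc(F)c(Br)c2)cc1NC(=O)NC1CCCCC1`: in an assay on isolated protein for inhibition of Indoleamine 2,3-dioxygenase 1 (Homo sapiens) (a higher number here means a weaker inhibitor, a lower number a stronger inhibitor), compound 1 gives > 3000 nM, a limit of the assay.
Compound 2 `CCCCNC(=O)Nc1cc(/C(=N/O)Nc2ccc(F)c(Br)c2)ccc1N(CC(C)C)CC(C)C`: in this assay compound 2 gives > 3000 nM, again a limit.
Compound 3 `CCCNC(=O)Nc1cc(/C(=N/O)Nc2ccc(F)c(Br)c2)ccc1N(CC(C)C)CC(C)C`: in this assay compound 3 gives 2900 nM.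

Among the measured compounds shown here, compound 3 thus holds the only number in this assay; the two other values shown are limits (the limit of > 3000 nM in this assay, at which 2 of the 3 values shown sit). The steps of an at least 1.0-fold lower number from compound 1 to compound 3 (0.01 log units; that floor lies within the scatter) and an at least 1.0-fold lower number from compound 2 to compound 3 (0.01 log units; that floor lies within the scatter) lie within the scatter, and the pair a step that the two limits leave unreadable from compound 1 to compound 2.

Compound 4 `Cc1ccc(NC(=O)Nc2cc(/C(=N/O)Nc3ccc(F)c(Br)c3)ccc2N(CC(C)C)CC(C)C)cc1` differs from compound 3 in one place: 4-methylphenyl in place of propyl on an amide-type nitrogen. For the measured compounds named here, none of the measured steps carries an aromatic group onto this nitrogen; the three substituents tried there all land at or near the limit, so no step beyond the scatter is expected in this assay. Compound 4 is therefore expected at 3200 nM, with a range from 1000 nM to 10000 nM. That estimate amounts to a step of a 1.1-fold higher number from compound 3 to compound 4 (0.04 log units; within the scatter), which is expected to stay within the scatter.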

Compound 4, half-maximal inhibitory concentration: 2300 nM
For compound 4 the middle estimate is 1.4-fold (0.14 log units) above the measured one, within the range that was stated.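

Among the compounds shown here, with 4-methylphenyl on the amide-type nitrogen, an aromatic ring now stands where the earlier compounds carry only propyl, butyl or cyclohexyl, and this assay shows a 1.3-fold lower number from compound 3 to compound 4 (0.10 log units; within the scatter). Against compound 2 and compound 1, whose values are limits, the floors are an at least 1.3-fold lower number from compound 2 to compound 4 (0.11 log units; that floor lies within the scatter) and an at least 1.3-fold lower number from compound 1 to compound 4 (0.11 log units; that floor lies within the scatter). Exchanging a saturated group for this aromatic ring therefore gives no step beyond the scatter, and the series stays close to the limit: the limit of > 3000 nM in this assay, at which 2 of the 4 values shown sit.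

Still open, on these data alone, is whether a 4-aminophenyl or 4-carboxyphenyl group in place of 4-methylphenyl gives a step beyond the scatter. Also open, as far as these compounds go, is whether a benzyl group or a longer chain on this nitrogen does so.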